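This account rests on a few compounds, and the source may have more. Where it says the series, first, only, none or still open, it means among the compounds named here.

Compound 1 `CCCSc1nc(N/N=C/c2cc(OC)c(OC)c(OC)c2)c2nnn(Cc3ccccc3)c2n1` gives 9410 nM. Compound 2 `CCCSc1nc(N/N=C(\C)c2ccccc2O)c2nnn(Cc3ccc(F)cc3)c2n1` gives 11000 nM. Compound 3 `CCCSc1nc(N/N=C/c2c[nH]c3ccccc23)c2nnn(Cc3ccccc3)c2n1` gives 7410 nM.

All three numbers come from a functional assay on MGC-803 cells (Homo sapiens) for antiproliferative activity, read by MTT assay, with a stated time of 72 h; on this read-out higher numbers stand for weaker inhibition and lower numbers for stronger inhibition. Compound 2 carries the highest of the three numbers, yet its gaps to compound 1 and to compound 3 both fall within the scatter, so no ordering among them can be read. Compound 4 `CCCSc1nc(N/N=C(\C)c2ccccc2O)c2nnn(Cc3ccc(Br)cc3)c2n1` has not yet been measured. Against compound 2 it shows (bromo in place of fluoro on an aromatic carbon), bromo in place of fluoro on an aromatic carbon. Among the measured compounds shown here, no measured pair covers this exchange, so nothing in the data sets its size. The step from compound 2 to compound 4 is therefore expected to be a 1.2-fold lower number from compound 2 to compound 4 (0.09 log units; within the scatter), essentially none beyond the scatter. Compound 4 is estimated at 9000 nM, within 4000 nM to 20000 nM.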

Compound 4, half-maximal inhibitory concentration: 11300 nM
For compound 4 the middle estimate is 1.3-fold (0.10 log units) below the measured one; the range from low to high includes it.
By their numbers in this assay, from the lowest: compounds 3, 1, 2 and 4 (each within the scatter of the next).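

Among the compounds shown here, compounds 2 and 4 form the first pair here that differs in one place, and in this assay bromo in place of fluoro on an aromatic carbon, para to a large group, gives a 1.0-fold higher number from compound 2 to compound 4 (0.01 log units; within the scatter). At this position, the two halogens therefore cannot be told apart in this assay. No measurement bears on why this is so.

The compounds shown leave open whether an amine, a nitrile or a carboxylic acid at this position would read differently. They also leave open whether the same exchange would read alike with another group on the rest of the molecule.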